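Dropping a Methyl from the Benzoyl Group

The source may report more compounds than this note shows. Statements on the series, on what has been measured and on what is new or still open speak of the compounds shown alone.

Compound 2 `COc1cc(-c2nnc3n2NC(c2cccs2)C(C(=O)c2ccc(C)cc2)S3)cc(OC)c1OC`: 3700 nM
Compound 1 `COc1cc(C(=O)C2Sc3nnc(-c4cc(OC)c(OC)c(OC)c4)n3NC2c2ccco2)cc(OC)c1OC`: > 100000 nM

Among the compounds with values here, in a functional assay on HepG2 cells (Homo sapiens) for cytotoxicity, read by MTT assay, with a stated time of 48 h (on this read-out higher numbers stand for weaker inhibition and lower numbers for stronger inhibition), compound 2 gives 3700 nM, the only full number among the measured compounds. For compound 1 the result is > 100000 nM, which is a limit of this assay and not a number (the limit of > 100000 nM in this assay, at which 1 of the 2 values shown sits). Compound 3 `COc1cc(-c2nnc3n2NC(c2cccs2)C(C(=O)c2ccccc2)S3)cc(OC)c1OC` differs from compound 2 by hydrogen in place of methyl on an aromatic carbon. Within the data shown here, no measured pair shows this change, so the step in this assay is expected to stay within the usual scatter, with no clear direction. Compound 3 is therefore estimated at 5000 nM, between 1500 nM and 20000 nM. The expected step from compound 2 to compound 3 is a 1.4-fold higher number from compound 2 to compound 3 (0.13 log units; within the scatter).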

Compound 3, half-maximal inhibitory concentration: > 100000 nM
Compound 3: no number, only a limit (the forecaster's own chance of this, stated with the estimate: 10%); at least 20-fold (1.30 log units) between middle value and limit.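

In this assay the first pair differing in one place gives an at least 27-fold higher number from compound 2 to compound 3 (1.43 log units; beyond the scatter), so the methyl of the 4-methylphenyl group counts for far more than the scatter. Compound 3 gives > 100000 nM as a limit of the assay, not a number, so the step has a minimum but no known size: the limit of > 100000 nM in this assay, at which 2 of the 3 values shown sit. Losing this one methyl, para to a large group, leaves no measurable number.

On these data alone, whether an ethyl chain or an amine at this place would match the methyl remains open.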